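Swapping Isopropyl for Bromophenyl on a Shared Core

This account rests on a few compounds, and the source may have more. Where it says the series, first, only, none or still open, it means among the compounds named here.

Two compounds share one core and differ only in the group on a ring nitrogen. Compound 1 `Cc1cc(Nc2cccc(C(F)(F)F)c2)nc(SCc2nc3ccccc3[nH]2)n1` carries a trifluoromethylphenyl group there, while compound 2 `Cc1cc(NC(C)C)nc(SCc2nc3ccccc3[nH]2)n1` carries an isopropyl group. Both were run in a functional assay on MCF7 cells (Homo sapiens) for cytotoxicity, read by MTT assay, with a stated time of 72 h; on this read-out higher numbers stand for weaker inhibition and lower numbers for stronger inhibition. In this assay compound 1 reached only the limit, > 100000 nM, so no number is known for it. In this assay compound 2 likewise reached only the limit, > 100000 nM. Compound 2 thus stands at the same edge as the other value shown: the limit of > 100000 nM in this assay, at which 2 of the 2 values shown sit. Going by the values given here, with two limits and no numbers, no step between measured compounds can be drawn.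

Compound 3 `Cc1cc(Nc2ccc(Br)cc2)nc(SCc2nc3ccccc3[nH]2)n1` is the next compound to be measured. (4-bromophenyl in place of isopropyl on a nitrogen on an aromatic ring). Its nearest measured neighbour, compound 2, gives only a limit, and compound 1, with another aromatic group on the same nitrogen, gives only a limit as well. The step of a number no higher from compound 2 to compound 3 (the limit leaves the size open) is therefore expected to be none beyond the scatter, with the result most likely reported again as a limit. Compound 3 is expected to sit near 100000 nM, within a range from 30000 nM to 300000 nM.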

Compound 3, half-maximal inhibitory concentration: 38000 nM
Beside the measured number, compound 3's estimate is 2.6-fold (0.42 log units) above it; low and high end bracket the measured number.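

Replacing isopropyl with 4-bromophenyl on a nitrogen on an aromatic ring gives an at least 2.6-fold lower number from compound 2 to compound 3 (0.42 log units; beyond the scatter) in this assay. Going by these compounds alone, this is the first change on the shared core to yield a real number rather than a limit, so the group at this position can shift the cell read-out, although the true size of the step remains unknown. An aromatic ring on this nitrogen is not enough on its own, however, and compound 1 goes against any such simple rule: compound 1, with its trifluoromethylphenyl group, gives > 100000 nM, which is a limit and not a number, so its gap to compound 3 cannot be read. Even with this gain, the set still sits mostly at the weak edge: the limit of > 100000 nM in this assay, at which 2 of the 3 values shown sit.

As far as these compounds go, what remains open is whether the bromine or the ring carries the change, a question that a plain phenyl or a 4-chlorophenyl group on the same nitrogen could help to answer. From the compounds shown here alone, it is also open how a cyclic amine such as morpholine, or a longer carbon chain, would read in this place.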